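Long-chain enone esters: ring substituent swap toward compound 3

A few compounds are considered here, and "the series" means these few. Any claim that something is new, unique, unknown or untested is made for them only; others in the source may bear on it.

Measured so far:
compound 1, `CCCC(=O)OC[C@H]1O[C@H](C2CCCC=C2C)C=CC1=O`, 350 nM
compound 2, `CC/C=C\C/C=C\C/C=C\C/C=C\C/C=C\C/C=C\CCC(=O)OC[C@@H]1C=CC(=O)[C@@H](CC2=CCCCC2)O1`, 30000 nM

Going by the values given here, in a functional assay on LFCl2A cells (Rattus norvegicus) for cytotoxicity (a higher number here means a weaker inhibitor, a lower number a stronger inhibitor), compound 2 gives 30000 nM, the highest of the two numbers, with compound 1 at 350 nM; the two differ in more than one place, so no single step separates them. Compound 3, `CC/C=C\C/C=C\C/C=C\C/C=C\C/C=C\C/C=C\CCC(=O)OC[C@@H]1C=CC(=O)[C@@H](C2CCCC=C2C)O1`, carries 2-methylcyclohex-2-en-1-yl in place of (cyclohex-1-en-1-yl)methyl on a saturated ring carbon. Compound 1 also bears 2-methylcyclohex-2-en-1-yl, which is the only pointer available; the expected step of a 3.8-fold lower number from compound 2 to compound 3 (0.57 log units; beyond the scatter) is a modest move to a lower number, with wide uncertainty. Compound 3 is estimated at 8000 nM in this assay, range 1500 nM to 40000 nM.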

Compound 3, half-maximal inhibitory concentration: 65000 nM
The estimate for compound 3 lay 8.1-fold (0.91 log units) below the measured number, outside the stated range (above it).
By their numbers in this assay, from the lowest: compound 1; then compound 2; then compound 3.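

In this assay the ring carbon next to the ring oxygen does not tolerate every arrangement of these atoms equally: 2-methylcyclohex-2-en-1-yl in place of (cyclohex-1-en-1-yl)methyl gives (a 2.2-fold higher number from compound 2 to compound 3 (0.34 log units; beyond the scatter)) and a modest loss. The two groups match in every computed count, so the way the same atoms are joined is enough to move the number at this position. No supporting data explain this step. Still open, going by these compounds, is how a phenyl ring or an amine-bearing group would read at this position, and whether this step would repeat with a different ester chain.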